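Series notes: cytotoxicity step from compound 3 to compound 4

The compounds below may be only part of what the source reports. "The series", "measured", "known", "first", "only" and "open" are said of these compounds alone.

Compound 3 `O=C(/C=C/c1ccc2c(c1)B(O)OC2)c1ccc(O)cc1` stands at a limit in an ADME assay on L929 cells (Mus musculus) for cytotoxicity, read by resazurin assay, with a stated time of 72 h; on this read-out lower numbers stand for stronger inhibition and higher numbers for weaker inhibition: compound 3 gives > 10 ug/mL in this assay, a limit of the measurement and not a number. Compound 1 `O=C(/C=C/c1ccc2c(c1)B(O)OC2)c1ccccc1O` likewise gives > 10 ug/mL in this assay, again a limit. Within the data shown here, compound 2 `Cc1cccc(C(=O)/C=C/c2ccc3c(c2)B(O)OC3)c1` is the one member with a number, giving 8.56 ug/mL in this assay. The picture is summed up by the limit of > 10 ug/mL in this assay, at which 2 of the 3 values shown sit. The measured steps read an at least 1.1-fold lower number from compound 1 to compound 2 (0.06 log units; that floor lies within the scatter), an at least 1.1-fold higher number from compound 2 to compound 3 (0.06 log units; that floor lies within the scatter) and a step that the two limits leave unreadable from compound 1 to compound 3; none of them rises beyond the scatter, and each exchanges the group on a carbonyl carbon. Compound 4 `CCOC(=O)c1ccc(C(=O)/C=C/c2ccc3c(c2)B(O)OC3)cc1` differs from compound 3 by ethoxycarbonyl in place of hydroxy on an aromatic carbon. Among the measured compounds shown here, no measured step touches that position, and the three steps that exist give no readable direction, so nothing beyond the scatter is expected. The expected step for compound 4 is a step that the limit leaves unreadable from compound 3 to compound 4. Compound 4 is accordingly estimated at 12 ug/mL, with a range from 6 ug/mL to 25 ug/mL, and a fair chance that this assay again reports only a limit.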

Compound 4, half-maximal inhibitory concentration: > 10 ug/mL
Compound 4 was reported as a limit; the forecaster's own chance of this, stated with the estimate: 55%; the middle value is on the limit's open side.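

In this assay compound 4 gives > 10 ug/mL, a limit and not a number. Compound 3 also stands at a limit, so no step can be read between compound 3 and compound 4. The compounds shown leave open whether ethoxycarbonyl in place of hydroxy on an aromatic carbon shifts this read-out at all, and in which direction.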